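The source may hold more compounds than are shown below. What is called first, only, known or untested is meant among the compounds shown, and "the series" means these compounds.

Working notes on the series, all with the shared core and the amide nitrogen substituent varied. In a functional assay on PC-3 cells (Homo sapiens) for antiproliferative activity, read by MTT assay, with a stated time of 48 h (on this read-out lower numbers stand for stronger inhibition and higher numbers for weaker inhibition), compound 1 (`COc1ccc(CN(C(=O)CSc2nc3ccccc3s2)c2cc(OC)c(OC)c(OC)c2)cc1`) gives 8460 nM, compound 2 (`COc1ccc(CN(C(=O)CSc2nc3ccccc3s2)c2cc(OC)c(OC)c(OC)c2)cc1O`) gives 2110 nM and compound 3 (`COc1ccc(CN(C(=O)CSc2nc3ccccc3s2)c2cc(OC)c(OC)c(OC)c2)cc1F`) gives 20100 nM. Compound 3 holds the highest number of the three, with a 2.4-fold higher number from compound 1 to compound 3 (0.38 log units; beyond the scatter) as its shorter step and a 9.5-fold higher number from compound 2 to compound 3 (0.98 log units; beyond the scatter) as its longer one.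

The next entry is compound 4 (`COc1cc(N(Cc2ccc(Br)cc2)C(=O)CSc2nc3ccccc3s2)cc(OC)c1OC`). The change is 4-bromophenyl in place of 3-fluoro-4-methoxyphenyl on a saturated chain carbon bound to an amide-type nitrogen, which, cut one bond further out, reads 3-fluoro-4-methoxybenzyl to 4-bromobenzyl.

Only indirect guidance exists. The measured steps all touch this same benzyl group, but none removes the methoxy or introduces bromo. Besides the steps above, a 4.0-fold lower number from compound 1 to compound 2 (0.60 log units; beyond the scatter) shows what hydroxy in place of hydrogen does here. All three steps are modest, so a step of similar size is the reasonable expectation in this assay. With compound 3 at 20100 nM, the top of the measured numbers, a move toward a lower number is expected rather than a further rise.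

The expected step is a 2.2-fold lower number from compound 3 to compound 4 (0.35 log units; beyond the scatter), with wide uncertainty.

For compound 4 the estimated value is 9000 nM, with an expected range of 3000 nM to 25000 nM.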

Compound 4, half-maximal inhibitory concentration: > 80000 nM
Compound 4 ended at the assay's limit; the forecaster's own chance of this, stated with the estimate: 5%; middle value at least 8.8-fold (0.94 log units) away from the limit.
By their numbers in this assay, from the lowest: compound 2; then compound 1; then compound 3. At a limit, above all of these: compound 4.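

In this assay compound 4 gives > 80000 nM, which is a limit of the assay and not a number: the limit of > 80000 nM in this assay, at which 1 of the 4 values shown sits.

Going by these compounds alone, the replacement of methoxy by bromo on an aromatic carbon gives an at least 9.4-fold higher number from compound 1 to compound 4 (0.97 log units; beyond the scatter), and replacing the 3-hydroxy-4-methoxyphenyl group with 4-bromophenyl gives an at least 37-fold higher number from compound 2 to compound 4 (1.57 log units; beyond the scatter), so changes at this position are not confined to the modest steps seen among the earlier compounds. The change under test gives an at least 3.9-fold higher number from compound 3 to compound 4 (0.59 log units; beyond the scatter), and compound 4, the only one of the four without a methoxy group on the benzyl ring, is also the only one at the limit.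

The compounds shown do not separate the effect of losing the methoxy group from that of bringing in bromo, and each of the three steps gives only a lower bound on its true size. Also open, on these data alone, is whether 4-chlorobenzyl, or a benzyl group carrying an amine or a carboxylic acid, would give a value within the range of this assay at the same position.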